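Piperazine substituent swap on a benzamide thiocarbamate series

A few compounds are considered here, and "the series" means these few. Any claim that something is new, unique, unknown or untested is made for them only; others in the source may bear on it.

Measured compounds:
compound 1 `Nc1ccccc1NC(=O)c1ccc(CSC(=S)N2CCN(Cc3ccccn3)CC2)cc1` — 65.2%
compound 2 `CN(Cc1ccncc1)C(=S)SCc1ccc(C(=O)Nc2ccccc2N)cc1` — 83.2%
compound 3 `Nc1ccccc1NC(=O)c1ccc(CSC(=S)N2CCCC2)cc1` — 83.4%

In a functional assay on MGC-803 cells (Homo sapiens) for antiproliferative activity, read by CCK-8 assay, with a stated time of 72 h, tested at 8 uM (on this read-out higher numbers stand for a stronger effect at the one concentration tested and lower numbers for a weaker effect), compound 1 gives 65.2% and stands lowest of the three numbers. Compound 2 and compound 3 both lie beyond the scatter above it, and their own two values sit within the scatter of each other. Among the compounds with values here, the only single-point step measured so far is a number 0.2 percentage points higher from compound 2 to compound 3 (within the scatter), which concerns the group on the thiocarbonyl carbon, not the ring nitrogen that is changed here.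

Compound 4 `Nc1ccccc1NC(=O)c1ccc(CSC(=S)N2CCN(C3CCCCC3)CC2)cc1` is not yet measured. It differs from compound 1 as follows: cyclohexyl in place of (pyridin-2-yl)methyl on an amine nitrogen in a ring

Within the data shown here, no measured step touches the substituent on the ring amine nitrogen, so the step from compound 1 to compound 4 has no direct precedent. Among the measured compounds shown here, the single available step, from compound 2 to compound 3, was within the scatter, which gives no lean in either direction. The expectation is therefore a step of about a number 4.8 percentage points higher from compound 1 to compound 4 (within the scatter) in this assay, not clearly beyond the scatter, with a wide range to allow for either outcome. For compound 4 the estimated value in this assay is 70%, expected to fall between 50% and 88%.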

Compound 4, a percentage reported as inhibition, at one concentration (the size of the read-out at that concentration, not a potency): 75.3%
Compound 4: middle estimate off by 5.3 percentage points, on the low side; the measured number falls inside the stated range.
By their numbers in this assay, from the lowest: compound 1; then compounds 4, 2 and 3 (each within the scatter of the next).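

Working notes on the substituent on the amine nitrogen in the ring: in this assay the read-out moves with this group, with a number 10.1 percentage points higher from compound 1 to compound 4 (beyond the scatter), a modest step and the first measured at this position. The change removes the (pyridin-2-yl)methyl group, with its six-membered aromatic ring and its hydrogen-bond acceptor, and puts in cyclohexyl, a six-membered non-aromatic ring of carbon only, so neither the aromatic ring nor that acceptor is needed to keep the effect at the one concentration tested. No measurement at hand accounts for the size or direction of this step.

The step bundles several differences, and the compounds shown leave open whether it follows the loss of the pyridine nitrogen, the loss of aromaticity or the loss of the methyl link between ring and amine nitrogen. Benzyl and cyclohexylmethyl on the same nitrogen would pull these apart, while a plain methyl group or a hydroxyethyl chain there would show whether a six-membered ring at this position is required at all.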